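This account rests on a few compounds, and the source may have more. Where it says the series, first, only, none or still open, it means among the compounds named here.

In a functional assay on MCF7 cells (Homo sapiens) for antiproliferative activity (a higher number here means a weaker inhibitor, a lower number a stronger inhibitor), compound 2 `CC(C)=CCc1cc(C(=O)Nc2cc3ccc(OCCCN(C)C(C)C)c(C)c3oc2=O)ccc1O` gives 1050 nM and compound 3 `CC(C)=CCc1cc(C(=O)Nc2cc3ccc(OCCCN(C)C(C)(C)C)c(C)c3oc2=O)ccc1O` gives 1140 nM, so compound 3 stands level with compound 2. Compound 1 `CCCN(CCC)CCCOc1ccc2cc(NC(=O)c3ccc(O)c(CC=C(C)C)c3)c(=O)oc2c1C` is reported only as a limit of the assay, > 50000 nM. Compound 4 `CC(C)=CCc1cc(C(=O)Nc2cc3ccc(OCCCNC4CCCCC4)c(C)c3oc2=O)ccc1O` changes the amine at the end of the chain: cyclohexylamino in place of methyl(tert-butyl)amino on a saturated chain carbon, three bonds along the chain from an oxygen on an aromatic ring. Going by the values given here, three measured steps bear on this change. Two are large, an at least 47-fold lower number from compound 1 to compound 2 (1.67 log units; beyond the scatter) and an at least 43-fold lower number from compound 1 to compound 3 (1.64 log units; beyond the scatter), so the amine can move the number widely, whereas a 1.1-fold higher number from compound 2 to compound 3 (0.04 log units; within the scatter) shows that one added methyl can leave it unchanged. Among the compounds with values here, no measured compound carries a ring on this nitrogen, so a moderate rise in the number is expected in this assay. The expected step is a 1.8-fold higher number from compound 3 to compound 4 (0.24 log units; within the scatter). Compound 4 is estimated at 2000 nM, within an expected range of 600 nM to 12000 nM.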

Compound 4, half-maximal inhibitory concentration: 1070 nM
Compound 4: middle estimate off by 1.9-fold (0.27 log units), on the high side, within the range that was stated.
By their numbers in this assay, from the lowest: compounds 2, 4 and 3 (each within the scatter of the next). At a limit, above all of these: compound 1.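

In this assay, cyclohexylamino, the only amine here with a ring and with a hydrogen-bond donor, matches both open-chain amines that carry a methyl: a 1.1-fold lower number from compound 3 to compound 4 (0.03 log units; within the scatter) and a 1.0-fold higher number from compound 2 to compound 4 (0.01 log units; within the scatter). So neither the ring nor the loss of the methyl moves the number at this position. Dipropylamino alone stands apart, with an at least 46-fold lower number from compound 1 to compound 4 (1.66 log units; beyond the scatter), and this step rests on a limit of the assay: the limit of > 50000 nM in this assay, at which 1 of the 4 values shown sits.

The compounds shown leave open whether a morpholine, a piperidine or an unsubstituted amine would stay level with these three. They also leave open how a longer chain to the nitrogen would read.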